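Two inactive thiazolidinediones and a hybrid to predict

The source may report more compounds than this note shows. Statements on the series, on what has been measured and on what is new or still open speak of the compounds shown alone.

Compound 1 `O=C1NC(=O)/C(=C\c2ccc(OCC(=O)N3N=C(c4ccc(F)cc4)CC3c3ccc(F)cc3)cc2)S1`: > 50000 nM
Compound 2 `O=C1NC(=O)/C(=C\c2ccc(OCC(=O)N3N=C(c4ccc(F)cc4F)CC3c3ccco3)cc2)S1`: > 50000 nM

In an assay on cells for inhibition of histone deacetylase 8 (Homo sapiens), read by fluorescence, with a stated time of 30 min (a higher number here means a weaker inhibitor, a lower number a stronger inhibitor), compound 2 returns only a limit, > 50000 nM, and no number. Compound 1 likewise sits at a limit in this assay, > 50000 nM. So compound 2 stands at the upper edge of what this assay reports, and there is no measured step from which to read a trend, as the limit of > 50000 nM in this assay, at which 2 of the 2 values shown sit, shows. Compound 3 `O=C1NC(=O)/C(=C\c2ccc(OCC(=O)N3N=C(c4ccc(F)cc4F)CC3c3ccc(F)cc3)cc2)S1` carries the change (4-fluorophenyl in place of furan-2-yl on a saturated ring carbon), 4-fluorophenyl in place of furan-2-yl on a saturated ring carbon, making it a hybrid of compounds 1 and 2. Since both measured compounds reach the same limit, no step beyond the scatter is expected from compound 2 to compound 3 in this assay, expressed as a step that the limit leaves unreadable from compound 2 to compound 3. Compound 3 is therefore expected to give 100000 nM, within 40000 nM to 400000 nM, most likely reported again as a limit.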

Compound 3, half-maximal inhibitory concentration: > 50000 nM
Compound 3 was reported as a limit; the forecaster's own chance of this, stated with the estimate: 85%; the middle value is on the limit's open side.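

In this assay compound 3 gives > 50000 nM, a limit and not a number. The steps joining compound 3 to compound 1 and compound 2 therefore cannot be read: the limit of > 50000 nM in this assay, at which 3 of the 3 values shown sit.

The compounds shown leave open whether either change affects inhibition in this assay at all.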